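The source may report more compounds than this note shows. Statements on the series, on what has been measured and on what is new or still open speak of the compounds shown alone.

Measured so far:
Compound 2, `CC(C(=O)NCc1ccc(C(F)(F)F)cc1OCc1ccc(F)cc1)c1ccc(NS(C)(=O)=O)c(F)c1`: 0.5 nM
Compound 1, `CCCCN(C)c1cc(C(F)(F)F)ccc1CNC(=O)C(C)c1ccc(NS(C)(=O)=O)c(F)c1`: 1.2 nM

In an assay on CHO cells for antagonist activity at transient receptor potential cation channel subfamily V member 1 (Homo sapiens), read by FLIPR (a higher number here means a weaker inhibitor, a lower number a stronger inhibitor), compound 2 gives 0.5 nM, the lowest of the two numbers; compound 1, the nearest, gives 1.2 nM. The step of a 2.4-fold lower number from compound 1 to compound 2 (0.38 log units; beyond the scatter) was modest. Compound 3, `CC(C(=O)NCc1ccc(C(F)(F)F)cc1SC1CCCC1)c1ccc(NS(C)(=O)=O)c(F)c1`, is not yet measured. It differs from compound 2 by cyclopentylsulfanyl in place of (4-fluorobenzyl)oxy on an aromatic carbon. Within the data shown here, no measured step covers this exact change; the one known step at the same position, a 2.4-fold lower number from compound 1 to compound 2 (0.38 log units; beyond the scatter), was modest, so a modest step is expected here too, in an uncertain direction. For compound 3 the expected value in this assay is 1 nM, between 0.3 nM and 4 nM, a step of a 2.0-fold higher number from compound 2 to compound 3 (0.30 log units; within the scatter).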

Compound 3, inhibition constant: 0.3 nM
Compound 3: the middle estimate sits 3.3-fold (0.52 log units) above what was measured; the range from low to high includes it.
By their numbers in this assay, from the lowest: compounds 3 and 2 (each within the scatter of the next); then compound 1.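

In this assay, cyclopentylsulfanyl serves this position about as well as the larger (4-fluorobenzyl)oxy: the swap gives a 1.7-fold lower number from compound 2 to compound 3 (0.22 log units; within the scatter) and so leaves the two groups indistinguishable, even without the aromatic ring of the benzyl group. Replacing butyl(methyl)amino with the same group gives a 4.0-fold lower number from compound 1 to compound 3 (0.60 log units; beyond the scatter) and is a clearer change. No measurement here explains these results. A cyclopentyloxy group would test whether the sulfur link matters, while a methoxy group or a bare hydrogen would show how small the group here can be.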